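The source may hold more compounds than are shown below. What is called first, only, known or untested is meant among the compounds shown, and "the series" means these compounds.

Measured so far in an assay on membranes from brain for displacement of a labelled ligand from adenosine receptor A1 (Cavia porcellus); a lower number here means a stronger inhibitor, a higher number a weaker inhibitor: compound 1 `CCCn1c(=O)n(CC)c(=O)c2[nH]cnc21` gives 1400 nM; compound 2 `CCCCn1c(=O)[nH]c(=O)c2[nH]cnc21` gives 21400 nM; compound 3 `CCCn1c(=O)n(CC)c(=O)c2c1ncn2C` gives 11800 nM.

Compound 3 stands second highest of the three numbers in this assay; its nearest neighbour is compound 2, within the scatter, while compound 1 is clearly lower. Among the compounds with values here, the one single-point step, an 8.4-fold higher number from compound 1 to compound 3 (0.93 log units; beyond the scatter), is methyl in place of hydrogen on an aromatic nitrogen and weakens binding.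

Compound 4 `CCCCn1c(=O)c2c(ncn2C)n(CCC)c1=O` differs from compound 3 by ethyl in place of hydrogen on a saturated chain carbon, two bonds along the chain from an aromatic nitrogen. Within the data shown here, no measured step bears on this change: compound 1 and compound 2 differ from each other in more than one place, so their values cannot be read as a chain-length effect on their own. The methyl on the aromatic nitrogen, which compound 3 and compound 4 share, is already accounted for in the value of compound 3.

Among the measured compounds shown here, with no directly relevant step, the expectation is a small change; compound 4 is estimated at 7000 nM (range 2500 nM to 20000 nM), which means an expected step of a 1.7-fold lower number from compound 3 to compound 4 (0.23 log units; within the scatter).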

Compound 4, inhibition constant: 6000 nM
The estimate for compound 4 lay 1.2-fold (0.07 log units) above the measured number; the range from low to high includes it.
By their numbers in this assay, from the lowest: compound 1; then compounds 4, 3 and 2 (each within the scatter of the next, the first and the last beyond it).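

In this assay, ethyl in place of hydrogen on a saturated chain carbon, two bonds along the chain from an aromatic nitrogen, gives a 2.0-fold lower number from compound 3 to compound 4 (0.29 log units; within the scatter), so the two compounds cannot be told apart. Within the data shown here, this is the first single-place reading at this chain, as the earlier compounds offered only the step on the aromatic nitrogen, and it shows that ethyl to butyl is accommodated here without a shift beyond the usual scatter. Nothing in hand offers an explanation for this result.

Open, from the compounds shown here alone, is how far this tolerance extends: a hexyl chain or a terminal amine at the same place could behave differently. Also open, going by these compounds, is whether ethyl to butyl reads the same when the aromatic nitrogen carries hydrogen rather than methyl, as in compound 1.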